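Benzamido for Phenoxy on a Carboxylic Acid Scaffold

A few compounds are considered here, and "the series" means these few. Any claim that something is new, unique, unknown or untested is made for them only; others in the source may bear on it.

Of the compounds shown here, three have been measured in an assay for inhibition of inositol hexakisphosphate kinase 2 (Homo sapiens), read by colorimetric assay, coupled enzyme assay and malachite green, with a stated time of 120 min, in the presence of a further agent that is not named here; a higher number here means a weaker inhibitor, a lower number a stronger inhibitor. Compound 1 `CN(C)C(=O)/C=C/c1ccc2noc(-c3ccccc3)c2c1` gives 40300 nM, compound 2 `Cc1ccc(-c2onc3ccc(/C=C/C(=O)O)cc23)cc1` gives 6510 nM, and compound 3 `O=C(O)c1ccc2noc(-c3ccc(Oc4ccccc4)cc3)c2c1` gives 280 nM. Compound 3 stands lowest of the three, and its gaps to compound 2 and to compound 1 both lie beyond the scatter, so it is the most potent compound here. Compound 4 `O=C(O)c1ccc2noc(-c3ccc(NC(=O)c4ccccc4)cc3)c2c1` differs from compound 3 in one place: benzamido in place of phenoxy on an aromatic carbon. Among the compounds with values here, no measured pair shows this exchange, so there is no step to lean on. The acid on the shared core is kept, and both groups carry one six-membered aromatic ring of carbon only. The change is expected to be small, a 1.4-fold higher number from compound 3 to compound 4 (0.15 log units; within the scatter), with no clear direction. Compound 4 is estimated at 400 nM, with a range from 100 nM to 1600 nM.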

Compound 4, half-maximal inhibitory concentration: 580 nM
Beside the measured number, compound 4's estimate is 1.5-fold (0.16 log units) below it; the measured number falls inside the stated range.
By their numbers in this assay, from the lowest: compound 3; then compound 4; then compound 2; then compound 1.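

In this assay, within the data shown here, this is the first measured exchange at this place, para to a large group: benzamido in place of phenoxy gives a 2.1-fold higher number from compound 3 to compound 4 (0.32 log units; beyond the scatter) and so costs a modest amount of potency. The acid and the shared core stay the same, so the step belongs to this one exchange. No measurement shown here accounts for the step. As far as these compounds go, whether it follows from the amide hydrogen, the carbonyl or the larger group stays open. Anilino or benzyl at this place could help separate these parts.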